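Notes on the amide-substituent series at the chemokine receptor

A few compounds are considered here, and "the series" means these few. Any claim that something is new, unique, unknown or untested is made for them only; others in the source may bear on it.

Measured compounds:
compound 1 `C[C@@H]1CN(c2sc(C(F)(F)F)nc2-c2nc3cc(OCCO)ccc3[nH]2)CCN1C(=O)Cn1cnc2cccnc21` — 2.1 nM
compound 2 `C[C@@H]1CN(c2sc(C(F)(F)F)nc2-c2nc3ccccc3[nH]2)CCN1C(=O)Cn1cc(Cl)cn1` — 1.7 nM
compound 3 `Cc1nc(C)n(CC(=O)N2CCN(c3sc(C(F)(F)F)nc3-c3nc4ccc(OC5COC5)cc4[nH]3)C[C@H]2C)n1` — 68 nM

In a functional assay on CHO-K1 cells for antagonist activity at C-X-C chemokine receptor type 3 (Homo sapiens), read by FLIPR, with a stated time of 10 min, in the presence of a further agent that is not named here (on this read-out higher numbers stand for weaker inhibition and lower numbers for stronger inhibition), compound 2 gives 1.7 nM, the lowest number of the three. Compound 1 sits within the scatter of it, so the two cannot be told apart on this read-out. Compound 3 stands well beyond the scatter, the only one of the three that is clearly weaker. For the measured compounds named here, the three compounds differ in more than one place, so no single step among them can be isolated.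

Compound 4 `C[C@@H]1CN(c2sc(C(F)(F)F)nc2-c2nc3ccccc3[nH]2)CCN1C(=O)CN1CCC(F)(F)CC1` has not been measured. It differs from compound 2 in one place: 4,4-difluoropiperidin-1-yl in place of 4-chloro-1H-pyrazol-1-yl on a saturated chain carbon bound to a carbonyl carbon. A six-membered non-aromatic ring with one hetero atom enters where a five-membered aromatic ring with two hetero atoms left. Going by the values given here, nothing among the measured compounds covers this kind of exchange; compound 3 shows only that changes at this position can move the number a long way.

The step from compound 2 to compound 4 is expected to be modest and toward weaker inhibition, a 4.1-fold higher number from compound 2 to compound 4 (0.61 log units; beyond the scatter), with wide uncertainty. Compound 4 is estimated at 7 nM in this assay, in the range 1.5 nM to 40 nM.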

Compound 4, half-maximal inhibitory concentration: 15 nM
Compound 4: the middle estimate sits 2.1-fold (0.33 log units) below what was measured; measured number inside the range.
By their numbers in this assay, from the lowest: compounds 2 and 1 (each within the scatter of the next); then compound 4; then compound 3.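

In this assay, for the compounds shown here, the first step that can be read in one place is an 8.8-fold higher number from compound 2 to compound 4 (0.95 log units; beyond the scatter), with 4,4-difluoropiperidin-1-yl in place of 4-chloro-1H-pyrazol-1-yl on a saturated chain carbon bound to a carbonyl carbon. The step lies beyond the scatter, so this position does respond to the exchange, yet a five-membered aromatic ring is not essential for inhibition here: compound 4, with a six-membered non-aromatic ring, still gives 15 nM. Nothing available indicates which part of the exchange carries the step, whether ring size, loss of the aromatic ring, or replacement of chlorine by two fluorines.

Still open, on these data alone, is how an unsubstituted pyrazol-1-yl, a plain piperidin-1-yl or a morpholin-4-yl would read on the same core, and only such groups could separate the halogen from the ring in this step. Also open, as far as these compounds go, is whether the same exchange gives a step of similar size on the core of compound 1, which carries a further substituent on its fused ring system.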